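Replacing (2-methylphenyl)carbonyl with 2,5-dimethyl-1H-pyrrol-1-yl on the Shared Core

The compounds below may be only part of what the source reports. "The series", "measured", "known", "first", "only" and "open" are said of these compounds alone.

Compound 1, `COc1ccc2c(c1)C(n1ccccc1=O)=CC(C)(C)O2`, gives 5.99 in a functional assay (trachea) with Rattus norvegicus as the target; on this read-out lower numbers stand for lower potency and higher numbers for higher potency (the scale is a negative logarithm).
Compound 2, `CC(=O)c1ccc2c(c1)C(n1ccccc1=O)=CC(C)(C)O2`, gives 6.65 in this assay.
Compound 3, `Cc1ccccc1C(=O)c1ccc2c(c1)C(n1ccccc1=O)=CC(C)(C)O2`, gives 6.25 in this assay.

All three share one core and differ only in the group on one aromatic carbon. Compound 3 stands second highest of the three numbers: its nearest neighbour is compound 1, with a number 0.26 log units higher from compound 1 to compound 3 (within the scatter), a gap within the scatter; its furthest is compound 2, with a number 0.40 log units lower from compound 2 to compound 3 (beyond the scatter), a gap beyond the scatter. Among the measured compounds shown here, the only step clearly beyond the scatter is a number 0.66 log units higher from compound 1 to compound 2 (beyond the scatter).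

Compound 4, `Cc1ccc(C)n1-c1ccc2c(c1)C(n1ccccc1=O)=CC(C)(C)O2`, is not yet measured. It differs from compound 3 in one place: 2,5-dimethyl-1H-pyrrol-1-yl in place of (2-methylphenyl)carbonyl on an aromatic carbon.

For the measured compounds named here, no measured step puts a pyrrole at this position, so there is no direct precedent. What the three measured compounds show is that swapping the group on this carbon moves this assay only modestly in either direction. Without a closer guide, the step from compound 3 to compound 4 is expected to fall within that scatter: a number 0.05 log units lower from compound 3 to compound 4 (within the scatter). Compound 4 is therefore estimated at 6.2, with a range from 5.6 to 6.8.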

Compound 4, logarithm of the reciprocal of the active concentration, log(1/C): 6.78
The estimate for compound 4 lay 0.58 log units below the measured number; measured number inside the range.
By their numbers in this assay, from the lowest: compounds 1 and 3 (each within the scatter of the next); then compounds 2 and 4 (each within the scatter of the next).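

The 2,5-dimethyl-1H-pyrrol-1-yl group shows that this aromatic carbon can carry a ring-bearing group without a carbonyl and still reach the top pair of numbers in this assay: the change gives a clear gain over the (2-methylphenyl)carbonyl group (a number 0.53 log units higher from compound 3 to compound 4 (beyond the scatter)) and over the methoxy group (a number 0.79 log units higher from compound 1 to compound 4 (beyond the scatter)). Against the small acetyl group, the pyrrole makes no difference that can be told from the scatter (a number 0.13 log units higher from compound 2 to compound 4 (within the scatter)), so a carbonyl is not needed for a number at this level, and compound 3, which has a carbonyl, sits lower. Carrying an aromatic ring here is not enough to set the number either, as compound 3 and compound 4 both carry one, and nothing measured on these compounds explains the gain.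

The compounds shown leave open how much the two methyl groups on the pyrrole contribute, since only the dimethylated ring appears and the plain 1H-pyrrol-1-yl group would test this directly. They also leave open how an amine, a carboxylic acid or a longer alkyl chain on this aromatic carbon would compare with the acetyl and pyrrole groups.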